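Fluoro to Chloro on the Aminophenyl Ring of Compound 1

The compounds below may be only part of what the source reports. "The series", "measured", "known", "first", "only" and "open" are said of these compounds alone.

Compound 1 `COc1cc(OC)c(/C=C/S(=O)(=O)Cc2ccc(F)c(N)c2)c(OC)c1`: 2500 nM
Compound 2 `COc1ccc(N)cc1CS(=O)(=O)/C=C/c1c(OC)cccc1OC`: 25000 nM

In a functional assay on K562 cells (Homo sapiens) for cytotoxicity, read by trypan blue exclusion, with a stated time of 96 h (on this read-out lower numbers stand for stronger inhibition and higher numbers for weaker inhibition), compound 1 gives 2500 nM, the lower of the two numbers, while compound 2 gives 25000 nM, a gap beyond the scatter. These two compounds differ in more than one place, so their gap says little about a single substitution.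

Compound 3 `COc1cc(OC)c(/C=C/S(=O)(=O)Cc2ccc(Cl)c(N)c2)c(OC)c1` keeps the core of compound 1 and changes one substituent: chloro in place of fluoro on an aromatic carbon. This is chloro in place of fluoro on an aromatic carbon, ortho to an amino group and para to a large group, turning 3-amino-4-fluorophenyl into 3-amino-4-chlorophenyl. Among the compounds with values here, no measured pair shows this exchange, so the expectation starts from compound 1 at 2500 nM, with no firm direction and no change beyond the scatter foreseen. The estimated step is a 1.3-fold lower number from compound 1 to compound 3 (0.10 log units; within the scatter). For compound 3 the expected value is 2000 nM, within an estimated range of 600 nM to 7000 nM.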

Compound 3, half-maximal inhibitory concentration: 10 nM
For compound 3 the middle estimate is 200-fold (2.30 log units) above the measured one; the measured number lies below the stated range.
By their numbers in this assay, from the lowest: compound 3; then compound 1; then compound 2.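

In this assay the exchange of fluoro for chloro on the aromatic carbon, ortho to an amino group and para to a large group, gives a 250-fold lower number from compound 1 to compound 3 (2.40 log units; beyond the scatter) with the rest of the structure unchanged, so this single atom has a large effect on the read-out. The earlier pair could not show this, since compound 1 and compound 2 differ in more than one place and their gap could not be tied to any one position. Nothing available accounts for the size of this step.

The compounds shown leave open whether the drop is particular to chloro or would also appear with bromo, methyl or trifluoromethyl on this carbon. They also leave open whether compound 3 would keep its low number if a hydroxyl or an acetamide replaced the amino group.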